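A few compounds are considered here, and "the series" means these few. Any claim that something is new, unique, unknown or untested is made for them only; others in the source may bear on it.

In a functional assay on HCT-116 cells (Homo sapiens) for cytotoxicity, read by MTT assay, with a stated time of 72 h (on this read-out higher numbers stand for weaker inhibition and lower numbers for stronger inhibition), three compounds that share one core have been measured. Compound 1 `Cc1ccc(C)c(N2CCN(Cc3nnc(-c4cc(S(N)(=O)=O)c(SCc5ccccc5)cc4Cl)o3)CC2)c1` gives 17000 nM. Compound 2 `NS(=O)(=O)c1cc(-c2nnc(Cn3cc(-c4ccccc4)nn3)o2)c(Cl)cc1SCc1ccccc1` gives 75000 nM. Compound 3 `COc1ccc(-c2cn(Cc3nnc(-c4cc(S(N)(=O)=O)c(SCc5ccccc5)cc4Cl)o3)nn2)cc1` gives 190000 nM. Compound 2 therefore stands second highest of the three numbers: the step of a 2.5-fold higher number from compound 2 to compound 3 (0.40 log units; beyond the scatter) is a modest rise that goes beyond the scatter, while the number of compound 1 is lower than that of compound 2 by more than the scatter, though those two compounds differ in more than one place.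

Compound 4 `NS(=O)(=O)c1cc(-c2nnc(/C=C/c3ccc(Cl)cc3)o2)c(Cl)cc1SCc1ccccc1` is made from compound 2 by one change: 2-(4-chlorophenyl)ethenyl in place of (4-phenyl-1H-1,2,3-triazol-1-yl)methyl on an aromatic carbon. For the measured compounds named here, no measured pair shows this kind of exchange. Going by the values given here, the only single step in hand, a 2.5-fold higher number from compound 2 to compound 3 (0.40 log units; beyond the scatter), adds a methoxy group to the six-membered aromatic ring of carbon only inside the group that now leaves entirely, so it says little about what its replacement by 2-(4-chlorophenyl)ethenyl will do. With nothing that bears directly on the change, no step beyond the scatter in either direction can be predicted, and compound 4 is expected to land near compound 2, as a 1.5-fold lower number from compound 2 to compound 4 (0.18 log units; within the scatter) states. The number for compound 4 in this assay is estimated at 50000 nM, within a range from 12000 nM to 200000 nM that is wide for want of a guiding step.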

Compound 4, half-maximal inhibitory concentration: 12000 nM
Beside the measured number, compound 4's estimate is 4.2-fold (0.62 log units) above it; the range from low to high includes it.
By their numbers in this assay, from the lowest: compounds 4 and 1 (each within the scatter of the next); then compound 2; then compound 3.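

In this assay, a 6.3-fold lower number from compound 2 to compound 4 (0.80 log units; beyond the scatter) is the first step shown in which the whole group on the aromatic carbon of the five-membered aromatic ring with 2 nitrogen and 1 oxygen is exchanged, and it shows that the number responds to such an exchange by more than the scatter. The earlier 2.5-fold higher number from compound 2 to compound 3 (0.40 log units; beyond the scatter) only added a methoxy group inside (4-phenyl-1H-1,2,3-triazol-1-yl)methyl, so it could say nothing about removing that group altogether. This exchange alters several things at once, since the entering 2-(4-chlorophenyl)ethenyl brings a chlorine and a double bond and has 0 hydrogen-bond acceptors where the leaving group has 3, and no supporting measurement explains the step.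

On these data alone, it remains open which of these differences matters, and a plain 2-phenylethenyl group without the chlorine, or a saturated 2-(4-chlorophenyl)ethyl chain, would help to separate them. Also open, as far as these compounds go, is how the number would respond to an amine or a carboxylic acid on the six-membered aromatic ring of 2-(4-chlorophenyl)ethenyl.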